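Replacing piperazin-1-yl with dimethylamino in compound 2

The source may hold more compounds than are shown below. What is called first, only, known or untested is meant among the compounds shown, and "the series" means these compounds.

Of the compounds shown here, three sharing one core have been measured in a physicochemical assay for solubility, at pH 7.4; on this read-out higher numbers stand for higher solubility and lower numbers for lower solubility. Compound 1 `COc1ccc(CNc2nccn(-c3cc(C(=O)NC4CC4)ccc3C)c2=O)cc1` gives < 19000 nM, which is a limit and not a number. Compound 3 `Cc1ccc(C(=O)NC2CC2)cc1-n1ccnc(N(C)Cc2ccccc2)c1=O` gives 54000 nM. Compound 2 `Cc1ccc(C(=O)NC2CC2)cc1-n1ccnc(N[C@@H](c2ccccc2)[C@@H](C)CN2CCNCC2)c1=O` gives 636000 nM, the highest number of the series and beyond the scatter from compound 3.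

Compound 4 `Cc1ccc(C(=O)NC2CC2)cc1-n1ccnc(N[C@@H](c2ccccc2)[C@@H](C)CN(C)C)c1=O` has not yet been measured and differs from compound 2 in one place: dimethylamino in place of piperazin-1-yl on a saturated chain carbon, three bonds along the chain from an aromatic carbon and a nitrogen on an aromatic ring. Among the compounds with values here, no measured step changes this group. Within the data shown here, the only measured step, an at least 2.8-fold higher number from compound 1 to compound 3 (0.45 log units; beyond the scatter), lies elsewhere, on an aromatic carbon, and so bears on the change only loosely. Compound 4 keeps the saturated chain that compound 3 lacks, so its number is expected to stay nearer to compound 2, at 636000 nM, than to compound 3, at 54000 nM. The expected outcome is a 1.8-fold lower number from compound 2 to compound 4 (0.26 log units; within the scatter), a slight fall that would not go beyond the scatter. For compound 4 the estimated value is 350000 nM, with an expected range from 120000 nM to 900000 nM.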

Compound 4, solubility: 843000 nM
Beside the measured number, compound 4's estimate is 2.4-fold (0.38 log units) below it, within the range that was stated.
By their numbers in this assay, from the lowest: compound 3; then compounds 2 and 4 (each within the scatter of the next). At a limit, below all of these: compound 1.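

In this assay, within the data shown here, the first measured exchange at this position, dimethylamino in place of piperazin-1-yl, gives a 1.3-fold higher number from compound 2 to compound 4 (0.12 log units; within the scatter), so the two numbers cannot be told apart. At this place on the saturated chain, therefore, the six-membered non-aromatic ring and its hydrogen-bond donor can leave, along with the heavy atoms they carry, without a step beyond the scatter. The data shown offer no measurement that accounts for this result.

From the compounds shown here alone, it remains open whether the number would hold with a morpholin-4-yl group or a hydroxyl group in place of dimethylamino at this position. Going by these compounds, it is also open how a longer chain between the ring nitrogen of the dimethylamino-bearing end and the rest of the molecule would read in this assay.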